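Alkoxy against cyclopentylamino on the shared core

The compounds below may be only part of what the source reports. "The series", "measured", "known", "first", "only" and "open" are said of these compounds alone.

Compound 1, `CCCCCCCCOc1nc(N)nc2c1ncn2/C=C1/CC1(CO)CO`: in an ADME assay on HFF cells (Homo sapiens) for cytotoxicity, with a stated time of 8 days (a higher number here means that more compound is tolerated, a lower number that less compound is tolerated), compound 1 reaches the limit > 300000 nM.
Compound 2, `CCCCCOc1nc(N)nc2c1ncn2/C=C1/CC1(CO)CO`: in this assay compound 2 gives 259000 nM.
Compound 3, `Nc1nc(NC2CCCC2)c2ncn(/C=C3/CC3(CO)CO)c2n1`: in this assay compound 3 reaches the limit > 300000 nM.

Compound 3 stands only at a limit in this assay, the ceiling (the limit of > 300000 nM in this assay, at which 2 of the 3 values shown sit), so it cannot be ranked against the others. Compound 4, `CCCCCCOc1nc(N)nc2c1ncn2/C=C1/CC1(CO)CO`, differs from it by hexyloxy in place of cyclopentylamino on an aromatic carbon. Within the data shown here, the steps that bear on this are an at least 1.1-fold higher number from compound 2 to compound 3 (0.06 log units; that floor lies within the scatter), a step that the two limits leave unreadable from compound 1 to compound 3 and, between the two alkoxy compounds, an at least 1.1-fold lower number from compound 1 to compound 2 (0.06 log units; that floor lies within the scatter); none of them is readable beyond the scatter. Hexyloxy sits between pentyloxy and octyloxy in chain length. The step of an at least 1.0-fold lower number from compound 3 to compound 4 (0.01 log units; that floor lies within the scatter) is therefore expected to stay within the scatter. For compound 4 the expected value is 290000 nM, in the range 150000 nM to 300000 nM.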

Compound 4, half-maximal cytotoxic concentration: > 200000 nM
Compound 4: only a limit was reported (the forecaster's own chance of this, stated with the estimate: 50%); the middle value is on the limit's open side.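

In this assay, among these compounds, compound 4 gives only the limit > 200000 nM, so no step linking it to compound 1, compound 2 or compound 3 can be read. As far as these compounds go, whether hexyloxy differs from cyclopentylamino, pentyloxy or octyloxy on the shared core stays open.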